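The source may hold more compounds than are shown below. What is called first, only, known or untested is meant among the compounds shown, and "the series" means these compounds.

Measured compounds:
compound 1, `CC1=CCC[C@H]2[C@](C)(CC3=CC(=O)C=C(N[C@@H](C(=O)O)C(C)C)C3=O)[C@@H](C)CC[C@]12C`, 85400 nM
compound 2, `CC(C)[C@@H](NC1=CC(=O)C=C(C(C)(C)C)C1=O)C(=O)O`, > 200000 nM, a limit of the assay
compound 3, `CSCC[C@H](NC1=CC(=O)C=C(C(C)(C)C)C1=O)C(=O)O`, > 200000 nM, a limit of the assay

In an ADME assay on MRC5 cells (Homo sapiens) for cytotoxicity, read by MTT assay, with a stated time of 72 h (a higher number here means a weaker inhibitor, a lower number a stronger inhibitor), compound 1 gives 85400 nM. Compound 2 gives > 200000 nM, which is a limit of this assay and not a number. Compound 3 gives > 200000 nM, again a limit. Among the compounds with values here, compound 1 therefore stands as the only compound with an actual number in this assay, with the other two sitting at the limit of > 200000 nM in this assay, at which 2 of the 3 values shown sit.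

The next compound, compound 4, `CC1=CCC[C@H]2[C@](C)(CC3=CC(=O)C=C(NCC(=O)O)C3=O)[C@@H](C)CC[C@]12C`, has not yet been measured. It differs from compound 1 in one place: hydrogen in place of isopropyl on a saturated chain carbon bound to an amine nitrogen and a carbonyl carbon. Within the data shown here, no pair of measured compounds differing in a single place is available, so the size of this change has no measured precedent here. Given that compound 1 is itself weak in this assay with 85400 nM, the step from compound 1 to compound 4 is expected to be small, most likely toward a weaker value or within the scatter, estimated at a 1.4-fold higher number from compound 1 to compound 4 (0.15 log units; within the scatter). Compound 4 is expected to give about 120000 nM, within a range of 50000 nM to 250000 nM.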

Compound 4, half-maximal inhibitory concentration: 183000 nM
Beside the measured number, compound 4's estimate is 1.5-fold (0.18 log units) below it; the range from low to high includes it.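

In this assay, the isopropyl on a saturated chain carbon bound to an amine nitrogen and a carbonyl carbon turns out to have a measurable part in the result: with hydrogen in its place, the reading is a 2.1-fold higher number from compound 1 to compound 4 (0.33 log units; beyond the scatter). Within the data shown here, this is the first comparison here of two compounds that differ in one place, and it shows that removing this branch leaves the compound modestly weaker, not unchanged, while the rest of the core of compound 1 stays the same. Compound 4 still gives an actual number, with little room left on this scale: the limit of > 200000 nM in this assay, at which 2 of the 4 values shown sit.

A single step cannot show how the result follows the size or nature of the group at this carbon, and a methyl, a benzyl or a longer chain there could fall anywhere. As far as these compounds go, whether the same change would have a similar effect on a different core also remains open.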